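Aryl-tetrazole variation in a diaryl ether series

A few compounds are considered here, and "the series" means these few. Any claim that something is new, unique, unknown or untested is made for them only; others in the source may bear on it.

Three measured compounds share one core and differ only in the substituent on the outer phenyl ring of the diaryl ether. In an assay on microsomes from brain for inhibition of Fatty-acid amide hydrolase 1 (Rattus norvegicus), read by fluorescence and HPLC, with a stated time of 60 min (on this read-out higher numbers stand for weaker inhibition and lower numbers for stronger inhibition), compound 1 `CC(Oc1ccc(Oc2ccc(F)cc2)cc1)C(=O)Cn1nnc(-c2ccc(Cl)cc2)n1` gives 42 nM, compound 2 `CC(Oc1ccc(Oc2ccc(Cl)cc2)cc1)C(=O)Cn1nnc(-c2ccc(Cl)cc2)n1` gives 76 nM and compound 3 `CC(Oc1ccc(Oc2ccc(C(F)(F)F)cc2)cc1)C(=O)Cn1nnc(-c2ccc(Cl)cc2)n1` gives 300 nM. Compound 3 carries the highest number of the three: the step of a 7.1-fold higher number from compound 1 to compound 3 (0.85 log units; beyond the scatter) and the step of a 3.9-fold higher number from compound 2 to compound 3 (0.60 log units; beyond the scatter) both lie beyond the scatter, while a 1.8-fold higher number from compound 1 to compound 2 (0.26 log units; within the scatter) does not.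

Compound 4 `COC(=O)c1ccc(-c2nnn(CC(=O)C(C)Oc3ccc(Oc4ccc(C(F)(F)F)cc4)cc3)n2)cc1` departs from compound 3 at a different place: methoxycarbonyl in place of chloro on an aromatic carbon, para to a large group. Among the measured compounds shown here, none of the measured steps touches this ring, so the three steps above bear on the change only indirectly, showing that single para substituent swaps have moved this assay by modest amounts. The step of a 1.7-fold higher number from compound 3 to compound 4 (0.22 log units; within the scatter) is therefore expected to be modest and uncertain in direction, with a lean toward a higher number.

For compound 4 the estimate in this assay is 500 nM, expected within 150 nM to 2000 nM.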

Compound 4, half-maximal inhibitory concentration: 130 nM
Estimate against measurement, compound 4: 3.8-fold (0.59 log units) above, outside the stated range (below it).
By their numbers in this assay, from the lowest: compounds 1, 2 and 4 (each within the scatter of the next, the first and the last beyond it); then compound 3.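

In this assay, among the compounds shown here, the change from 4-chlorophenyl to 4-(methoxycarbonyl)phenyl gives a 2.3-fold lower number from compound 3 to compound 4 (0.36 log units; beyond the scatter), so this position, untouched by the earlier steps, also moves the read-out. Methoxycarbonyl, with four heavy atoms against one for chloro and two hydrogen-bond acceptors against none, is accepted here with a modest gain in inhibition and no loss. No measurement at hand accounts for the direction of this step.

From the compounds shown here alone, the step is read only with trifluoromethyl on the outer phenyl ring, and whether it holds with the fluoro of compound 1 or the chloro of compound 2 remains open. Also open, going by these compounds, is how a carboxylic acid, a primary amide or a nitrile in place of methoxycarbonyl would compare.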